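A few compounds are considered here, and "the series" means these few. Any claim that something is new, unique, unknown or untested is made for them only; others in the source may bear on it.

Measured so far: compound 1 `CCCCc1ccc(CNC(C)=O)c(=O)n1Cc1ccc(-c2ccccc2-c2nn[nH]n2)cc1`, compound 2 `CCCCc1ccc(CN(Cc2ccccc2)S(=O)(=O)c2ccc(C)cc2)c(=O)n1Cc1ccc(-c2ccccc2-c2nn[nH]n2)cc1`, compound 3 `CCCCc1ccc(CN(Cc2ccccc2)S(=O)(=O)c2ccccc2)c(=O)n1Cc1ccc(-c2ccccc2-c2nn[nH]n2)cc1`.

In a functional assay (aorta) for antagonist activity, with Oryctolagus cuniculus as the target (a higher number here means a weaker inhibitor, a lower number a stronger inhibitor), compound 1 gives 3 nM, the lowest of the three numbers. Compound 3 gives 20 nM and compound 2 gives 60 nM; both carry an arylsulfonyl group on a benzyl-bearing nitrogen where compound 1 carries the acetamido. Among the measured compounds shown here, the only single-point step measured is a 3.0-fold lower number from compound 2 to compound 3 (0.48 log units; beyond the scatter), which concerns the aryl of the sulfonyl and bears only loosely on the change at hand. Compound 4 `CCCCc1ccc(CN(CC)S(C)(=O)=O)c(=O)n1Cc1ccc(-c2ccccc2-c2nn[nH]n2)cc1` differs from compound 1 by ethyl(methylsulfonyl)amino in place of acetamido on a saturated chain carbon bound to an aromatic carbon. It is a sulfonamide like compounds 2 and 3, but with shorter groups on nitrogen and sulfur; the values of compounds 2 and 3 place sulfonamides of this series above compound 1. The expected step is therefore a 3.3-fold higher number from compound 1 to compound 4 (0.52 log units; beyond the scatter), a moderate rise. Compound 4 is estimated at 10 nM, range 3 nM to 40 nM.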

Compound 4, half-maximal inhibitory concentration: 2 nM
Estimate against measurement, compound 4: 5.0-fold (0.70 log units) above; the measured number lies below the stated range.
By their numbers in this assay, from the lowest: compounds 4 and 1 (each within the scatter of the next); then compound 3; then compound 2.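

At this position, on a saturated chain carbon bound to an aromatic carbon, the change to ethyl(methylsulfonyl)amino from acetamido gives a 1.5-fold lower number from compound 1 to compound 4 (0.18 log units; within the scatter) in this assay and so leaves the two groups level. The larger group, without the hydrogen-bond donor of acetamido, is tolerated here, so neither that donor nor the smaller size of acetamido is required for a low number in this assay. Nothing available explains why the two groups read alike.

Ethyl and methylsulfonyl change together, so their separate contributions remain open. Also open, going by these compounds, is how a carboxylic acid or a primary amine would read in this place.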